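Notes on the step to compound 4

The source may hold more compounds than are shown below. What is called first, only, known or untested is meant among the compounds shown, and "the series" means these compounds.

Values in a functional assay on HFF cells (Homo sapiens) for cytotoxicity; a higher number here means a weaker inhibitor, a lower number a stronger inhibitor:
compound 1 `Cc1ccc(S(=O)(=O)NN2C(=S)S/C(=C\c3ccc(Cl)c(Cl)c3)C2O)cc1`: > 100000 nM
compound 2 `COc1ccc(S(=O)(=O)NN2C(=S)S/C(=C\c3ccc(Cl)c(Cl)c3)C2O)cc1`: > 100000 nM
compound 3 `Cc1cccc(/C=C2\SC(=S)N(NS(=O)(=O)c3ccccc3)C2=O)c1`: > 100000 nM

None of these is a number; each is a limit of the assay, and (the limit of > 100000 nM in this assay, at which 3 of the 3 values shown sit). Compound 3 therefore stands at a limit, > 100000 nM, and no exact position can be given for it.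

The next structure is compound 4 `O=C1/C(=C/c2ccc(Br)c(Br)c2)SC(=S)N1NS(=O)(=O)c1ccccc1`. The change is 3,4-dibromophenyl in place of 3-methylphenyl on a double-bonded chain carbon bound to a double-bonded ring carbon.

One measured step exists, a step that the two limits leave unreadable from compound 1 to compound 2. It is a different change, methoxy in place of methyl on an aromatic carbon, and it gives no size to carry over. The expectation rests on compound 3 and its limit of > 100000 nM. No step beyond the scatter is expected in this assay, and no direction can be assigned.

The expected step is a number no higher from compound 3 to compound 4 (the limit leaves the size open).

For compound 4 the estimate is 100000 nM, with an expected range of 30000 nM to 300000 nM.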

Compound 4, half-maximal inhibitory concentration: > 100000 nM
Compound 4 ended at the assay's limit; the forecaster's own chance of this, stated with the estimate: 80%; the middle value sits exactly at the limit.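

In this assay compound 4 gives > 100000 nM as a limit of the assay, not a number. Compound 3 also sits at a limit, so no step can be read from compound 3 to compound 4. The compounds shown leave open whether either structural change alters the value in this assay at all.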